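The source may hold more compounds than are shown below. What is called first, only, known or untested is meant among the compounds shown, and "the series" means these compounds.

Measured compounds in an ADME assay on Vero cells (Chlorocebus sabaeus) for cytotoxicity, read by MTT assay, with a stated time of 72 h; on this read-out higher numbers stand for lower toxicity in this test and lower numbers for higher toxicity in this test:

Compound 1, `CC(C)CN(CC(C)C)N1CCN(c2nc(=O)c3cc(C(F)(F)F)cc([N+](=O)[O-])c3s2)CC1`, gives only a limit of the assay, > 64 ug/mL.
Compound 2, `CN(CC1CCCCC1)N1CCN(c2nc(=O)c3cc(C(F)(F)F)cc([N+](=O)[O-])c3s2)CC1`, likewise reaches only a limit of the assay, > 64 ug/mL.
Compound 3, `O=c1nc(N2CCN(NCc3ccc(OC(F)(F)F)cc3)CC2)sc2c([N+](=O)[O-])cc(C(F)(F)F)cc12`, also sits at a limit of the assay, > 64 ug/mL.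

On the numbers shown, compound 3 therefore stands where every measured compound in the series stands: at the limit rather than at a number, and nothing separates it from compound 1 or compound 2 on this read-out. All three values sit at the limit of > 64 ug/mL in this assay, at which 3 of the 3 values shown sit.

Compound 4, `Cc1cccc(F)c1CNN1CCN(c2nc(=O)c3cc(C(F)(F)F)cc([N+](=O)[O-])c3s2)CC1`, differs from compound 3 in one place: 2-fluoro-6-methylphenyl in place of 4-(trifluoromethoxy)phenyl on a saturated chain carbon bound to an amine nitrogen. Among the measured compounds shown here, the only measured single-site step, a step that the two limits leave unreadable from compound 1 to compound 2, changes the substituent on the same amine nitrogen in a ring, but both of its ends are limits, so its size cannot be read. For the measured compounds named here, no measured step informs the swap of one benzyl substituent for another at this position. The expectation for compound 4 in this assay is therefore that it behaves as its neighbours do and again returns a limit, with an estimated step of a number no higher from compound 3 to compound 4 (the limit leaves the size open) of no readable size. Compound 4 is estimated at 64 ug/mL, within 32 ug/mL to 128 ug/mL.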

Compound 4, half-maximal cytotoxic concentration: > 64 ug/mL
Compound 4 gave a limit, no number (the forecaster's own chance of this, stated with the estimate: 80%); the middle value sits exactly at the limit.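

No new step can be read in this assay, since compound 4 gives a limit, as do compound 1, compound 2 and compound 3, and the steps joining them cannot be sized: the limit of > 64 ug/mL in this assay, at which 4 of the 4 values shown sit.

The compounds shown leave open how far any of the four lies from that limit, and whether 2-fluoro-6-methylphenyl in place of 4-(trifluoromethoxy)phenyl shifts the read-out at all.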